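The source may hold more compounds than are shown below. What is called first, only, known or untested is meant among the compounds shown, and "the series" means these compounds.

Compound 1 `COc1cc2ncnc(Nc3ccc(F)c(Cl)c3)c2cc1OCCCCC(=O)Nc1ccc(S(N)(=O)=O)cc1` has the highest number among three close analogues in a functional assay on NCI-H1975 cells (Homo sapiens) for antiproliferative activity, read by MTT assay, with a stated time of 72 h (a higher number here means a weaker inhibitor, a lower number a stronger inhibitor), where compound 1 gives 35600 nM. Compound 2 `COc1cc2ncnc(Nc3cccc(Cl)c3)c2cc1OCCCCC(=O)Nc1ccc(S(N)(=O)=O)cc1` gives 33200 nM, and compound 3 `COc1cc2ncnc(Nc3ccc(Cl)cc3)c2cc1OCCCCC(=O)Nc1ccc(S(N)(=O)=O)cc1` gives 31800 nM. The steps of a 1.1-fold lower number from compound 1 to compound 2 (0.03 log units; within the scatter) and a 1.1-fold lower number from compound 1 to compound 3 (0.05 log units; within the scatter) both sit within the scatter, so the three compounds cannot be told apart on these numbers. Compound 4 `COc1ccc(Nc2ncnc3cc(OC)c(OCCCCC(=O)Nc4ccc(S(N)(=O)=O)cc4)cc23)cc1OC` differs from compound 1 in 3,4-dimethoxyphenyl in place of 3-chloro-4-fluorophenyl on a nitrogen on an aromatic ring. Among the compounds with values here, no measured step brings in the 3,4-dimethoxyphenyl, but the two steps that altered the same ring moved nothing beyond the scatter, so compound 4 is expected to show a step of about a 1.1-fold higher number from compound 1 to compound 4 (0.05 log units; within the scatter), which amounts to no real change. Compound 4 is accordingly estimated at 40000 nM, with a range from 15000 nM to 110000 nM.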

Compound 4, half-maximal inhibitory concentration: 9230 nM
Beside the measured number, compound 4's estimate is 4.3-fold (0.64 log units) above it; the whole stated range lies above it.
By their numbers in this assay, from the lowest: compound 4; then compounds 3, 2 and 1 (each within the scatter of the next).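

In this assay this position on the nitrogen proves able to move the number beyond the scatter, with a 3.9-fold lower number from compound 1 to compound 4 (0.59 log units; beyond the scatter) and a 3.6-fold lower number from compound 2 to compound 4 (0.56 log units; beyond the scatter) and a 3.4-fold lower number from compound 3 to compound 4 (0.54 log units; beyond the scatter) for the 3,4-dimethoxyphenyl group. The changes among the chlorophenyl and 3-chloro-4-fluorophenyl groups had shown no such movement, so the flat result among compounds 1, 2 and 3 does not hold for this position as a whole. Nothing available accounts for the step.

On these data alone, whether a phenyl carrying a single methoxy group would be enough remains open. So does the outcome with a hydroxy group or a longer ethoxy chain in place of the methoxy groups.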